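A few compounds are considered here, and "the series" means these few. Any claim that something is new, unique, unknown or untested is made for them only; others in the source may bear on it.

Measured so far in an ADME assay on TZM cells (Homo sapiens) for cytotoxicity, with a stated time of 1 days; on this read-out higher numbers stand for lower toxicity in this test and lower numbers for higher toxicity in this test:

Compound 1 `Cc1cc(C#N)cc(C)c1Oc1nc(Nc2ccc(C#N)cc2)ncc1/C=C/C(N)=O` — compound 1 gives > 243 nM, a limit of this assay.
Compound 2 `Cc1cc(C#N)cc(C)c1Oc1nc(Nc2ccc(C#N)cc2)ncc1/C=C/C(=O)NCC1CCN(S(C)(=O)=O)CC1` — compound 2 gives > 171 nM, again a limit.

Among the compounds with values here, compound 2 thus stands on no number at all: its result in this assay is a limit, and the only other value, that of compound 1, is a limit as well. The step that the two limits leave unreadable from compound 1 to compound 2 is therefore unreadable; both ends sit at a limit, the limit of > 171 nM in this assay, at which 1 of the 2 values shown sits, and (the limit of > 243 nM in this assay, at which 1 of the 2 values shown sits).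

Compound 3 `Cc1cc(C#N)cc(C)c1Oc1nc(Nc2ccc(C#N)cc2)ncc1/C=C/C(=O)NCCN1CCN(S(C)(=O)=O)CC1` carries the change ((4-(methylsulfonyl)piperazin-1-yl)methyl in place of 1-(methylsulfonyl)piperidin-4-yl on a saturated chain carbon bound to an amide-type nitrogen). Within the data shown here, only one measured step exists in this assay, and it bears on the new compound merely by sharing the amide nitrogen as the place of change; its size is not readable, so it gives no direction and no magnitude.

For compound 3 the expectation is that this assay again returns a limit, so the step that the limit leaves unreadable from compound 2 to compound 3 is expected to be none beyond the scatter. Compound 3 is estimated at 250 nM, with the range 150 nM to 500 nM.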

Compound 3, half-maximal cytotoxic concentration: > 166 nM
Compound 3 gave a limit, no number (the forecaster's own chance of this, stated with the estimate: 85%); the middle value is on the limit's open side.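

In this assay compound 3 gives > 166 nM, a limit of the assay. Compound 1 and compound 2 also stand at limits, so the steps linking compound 3 to compound 1 and to compound 2 cannot be read. The compounds shown leave open where the half-maximal cytotoxic concentration of any of the three lies, and whether their amide substituents differ at all on this read-out.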